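The source may hold more compounds than are shown below. What is called first, only, known or untested is meant among the compounds shown, and "the series" means these compounds.

Compound 1, `O=C1Nc2ccc(S(=O)(=O)N3CCOCC3)cc2/C1=N/c1cccc(C(F)(F)F)c1`, was tested in a functional assay on HCT-116 cells (Homo sapiens) for cytotoxicity, read by sulforhodamine B assay, with a stated time of 24 h (a lower number here means a stronger inhibitor, a higher number a weaker inhibitor), where compound 1 gives 15900 nM. Two companions share its core. Compound 2, `O=C1Nc2ccc(S(=O)(=O)N3CCOCC3)cc2/C1=N/c1ccc(/N=C2\C(=O)Nc3ccc(S(=O)(=O)N4CCOCC4)cc32)cc1`, gives 7480 nM in this assay, and compound 3, `COc1ccc(-c2c(C#N)c(N)n(/N=C3\C(=O)Nc4ccc(S(=O)(=O)N5CCOCC5)cc43)c(=O)c2C#N)cc1`, gives 18100 nM. Among these three numbers compound 1 stands second highest: its value and that of compound 3 lie within the usual scatter of each other, while compound 2 shows a lower number that lies beyond the scatter. Going by the values given here, no pair of measured compounds differs in a single place, so the effect of any one change on its own remains unknown here.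

Compound 4, `CC(=O)N/N=C1\C(=O)Nc2ccc(S(=O)(=O)N3CCOCC3)cc21`, has not yet been measured in this assay. It differs from compound 1 in one place: acetamido in place of 3-(trifluoromethyl)phenyl on a double-bonded nitrogen. Every value known in this set sits in the weakly active range, and nothing in it shows how a small substituent on the double-bonded nitrogen fares. In this assay the expected change is a 1.9-fold higher number from compound 1 to compound 4 (0.28 log units; within the scatter), estimated as a modest move toward a higher number. Compound 4 is expected to give about 30000 nM, within a range from 10000 nM to 100000 nM.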

Compound 4, half-maximal inhibitory concentration: 29000 nM
Compound 4: middle estimate off by 1.0-fold (0.01 log units), on the high side; measured number inside the range.
By their numbers in this assay, from the lowest: compound 2; then compounds 1, 3 and 4 (each within the scatter of the next).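

Going by these compounds alone, compound 4 gives the first pair in this set that differs in one place, and so the first reading of this position on its own: in this assay, acetamido in place of 3-(trifluoromethyl)phenyl on a double-bonded nitrogen gives a 1.8-fold higher number from compound 1 to compound 4 (0.26 log units; within the scatter). The aromatic ring and its trifluoromethyl group can therefore leave this position, with a smaller group without a ring entering, and the shift stays within the usual scatter. No measured property bears on this result, so the pair offers no account of it.

From the compounds shown here alone, whether a simple amine, a carboxylic acid or a longer chain on this double-bonded nitrogen would shift the number beyond the scatter remains open. No pair differing in one place yet accounts for the lower number of compound 2.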